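The source may report more compounds than this note shows. Statements on the series, on what has been measured and on what is new or still open speak of the compounds shown alone.

Compound 1, with structure `C=C1C[C@]23C[C@@]1(O)CC[C@@H]2c1cccc(C)c1[C@@H]3Cn1cc(-c2ccccn2)nn1`, was tested in a functional assay on SW480 cells (Homo sapiens) for cytotoxicity, read by MTT assay, with a stated time of 4 days (a lower number here means a stronger inhibitor, a higher number a weaker inhibitor), where it gave > 20000 nM, which is a limit of the measurement rather than a number. Two related compounds give some sense of the range. Compound 2, `C=C1C(=O)[C@]23C[C@@]1(O)CC[C@H]2c1ccc(OS(=O)(=O)c2ccc(C)cc2)c(C)c1[C@@H]3Cn1cc(-c2ccc(F)cc2)nn1`, shows 1630 nM in this assay. Compound 3, `Cc1ccc(S(=O)(=O)Oc2ccc3c(c2C)[C@H](Cn2cc(-c4ccc(Br)cc4)nn2)[C@@]24CC(=O)[C@@](C)(CC[C@@H]32)C4)cc1`, reaches only > 20000 nM in this assay, again a limit. Compound 1 thus sits at the limit of > 20000 nM in this assay, at which 2 of the 3 values shown sit, so its own potency can only be placed at the weak end of what the measurement can report.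

Compound 4, `C=C1C[C@]23C[C@@]1(O)CC[C@@H]2c1cccc(C)c1[C@@H]3Cn1cc(-c2ccc(C)cc2)nn1`, differs from compound 1 in one place: 4-methylphenyl in place of pyridin-2-yl on an aromatic carbon. Within the data shown here, no pair of measured compounds differs only in this way, so the size of this step cannot be read from a measured pair, and the values of compound 2 and compound 3 each come with several other changes. Compound 4 is therefore expected to stay near where compound 1 stands, with the step of an at least 1.1-fold lower number from compound 1 to compound 4 (0.04 log units; that floor lies within the scatter) expected to lie within the usual scatter. The estimate for compound 4 is 18000 nM, in a range from 5000 nM to 60000 nM.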

Compound 4, half-maximal inhibitory concentration: > 20000 nM
Compound 4 gave a limit, no number (the forecaster's own chance of this, stated with the estimate: 60%); middle value at least 1.1-fold (0.04 log units) away from the limit.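

Compound 1 and compound 4 both give only a limit in this assay, not a number, so the step between them cannot be read. The compounds shown leave open whether 4-methylphenyl in place of pyridin-2-yl shifts potency at all, with both compounds resting at the same limit: the limit of > 20000 nM in this assay, at which 3 of the 4 values shown sit.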